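The compounds below may be only part of what the source reports. "The series", "measured", "known", "first", "only" and "open" are said of these compounds alone.

Compound 2 `CC1=CC[C@H](C(C)(C)NC(=S)N/N=C/c2ccc(N(C)C)cc2)CC1` is known in an ADME assay on Vero cells (Chlorocebus sabaeus) for inhibition, read by sulforhodamine B assay, with a stated time of 48 h (on this read-out higher numbers stand for weaker inhibition of growth and lower numbers for stronger inhibition of growth), only by a limit: in this assay compound 2 gives > 100000 nM. Its companion compound 1 `COc1ccc(/C=N/NC(=S)NC(C)(C)[C@H]2CC=C(C)CC2)cc1` gives 70100 nM in this assay, and the step of an at least 1.4-fold higher number from compound 1 to compound 2 (0.15 log units; that floor lies within the scatter) rests on (the limit of > 100000 nM in this assay, at which 1 of the 2 values shown sits). Compound 3 `CC1=CC[C@H](C(C)(C)NC(=S)N/N=C/c2ccc(F)cc2)CC1` differs from compound 2 by fluoro in place of dimethylamino on an aromatic carbon. Among the measured compounds shown here, the only measured step that bears on this change is the one from compound 1 to compound 2, which also exchanged the group on the aromatic carbon para to a large group, and no measured step involves fluoro. Compound 3 is therefore expected to move little beyond the scatter, an estimated step of an at least 1.1-fold lower number from compound 2 to compound 3 (0.07 log units; that floor lies within the scatter), giving an estimated value of 85000 nM within a range from 40000 nM to 200000 nM.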

Compound 3, concentration for total growth inhibition: > 100000 nM
Compound 3: only a limit was reported (the forecaster's own chance of this, stated with the estimate: 40%); at least 1.1-fold (0.07 log units) between middle value and limit.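

In this assay compound 3 gives only a limit, > 100000 nM. Fluoro in place of methoxy on this aromatic carbon gives an at least 1.4-fold higher number from compound 1 to compound 3 (0.15 log units; that floor lies within the scatter), so a second replacement of methoxy, much smaller than dimethylamino, reaches the same limit, and the step between compound 2 and compound 3 cannot be read. The values now gather at that limit: the limit of > 100000 nM in this assay, at which 2 of the 3 values shown sit.

The compounds shown leave open how far compound 2 and compound 3 actually lie from compound 1. They also leave open whether a hydroxyl, a chloro or a nitro group at this place would give a readable value.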